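Sulfonamide series, growth inhibition: tert-butyl gives way to phenyl

This account rests on a few compounds, and the source may have more. Where it says the series, first, only, none or still open, it means among the compounds named here.

Measured so far:
compound 1, `O=S(=O)(Nc1ccccc1)c1ccc(I)cc1`, gives 23000 nM in a functional assay on A549 cells (Homo sapiens) for inhibition; a higher number here means a weaker inhibitor of growth, a lower number a stronger inhibitor of growth
compound 2, `Cc1ccc(NS(=O)(=O)c2ccc(I)cc2)cc1O`, gives 15000 nM in this assay
compound 3, `Cc1cc(C2(c3ccccc3)C(=O)Nc3ccccc32)c(NS(=O)(=O)c2ccc(C(C)(C)C)cc2)cc1O`, gives 800 nM in this assay

Compound 3 stands at the lowest number of the three, and both gaps are beyond the scatter: compound 2 sits at a higher number, compound 1 higher still. Compound 3 is thus the strongest inhibitor of growth among the measured compounds. Within the data shown here, compounds 1 and 2 lack the large substituted core of compound 3 and carry iodine on the sulfonyl ring, so no single-point step between measured compounds is available to calibrate what a change on that ring does.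

Compound 4, `Cc1cc(C2(c3ccccc3)C(=O)Nc3ccccc32)c(NS(=O)(=O)c2ccc(-c3ccccc3)cc2)cc1O`, differs from compound 3 in one place: phenyl in place of tert-butyl on an aromatic carbon. Both groups leaving and entering carry no donors, no acceptors and no charge, and the rest of the molecule is untouched. With nothing measured on this ring for this core, no step beyond the scatter is expected in either direction. Compound 4 is therefore estimated at 800 nM, within 250 nM to 2500 nM, which is expected to mean a step of no change at the digits printed from compound 3 to compound 4 (within the scatter).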

Compound 4, concentration for 50% growth inhibition: 4000 nM
The estimate for compound 4 lay 5.0-fold (0.70 log units) below the measured number; measured number outside the range, above it.
By their numbers in this assay, from the lowest: compound 3; then compound 4; then compounds 2 and 1 (each within the scatter of the next).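

Phenyl in place of tert-butyl on this aromatic carbon, para to a large group, gives a 5.0-fold higher number from compound 3 to compound 4 (0.70 log units; beyond the scatter) in this assay, the first step in the series that isolates a single place. The position is therefore not indifferent to the group it carries, even though both groups have no hydrogen-bond donors, no hydrogen-bond acceptors and no net charge; on the shared core, the tert-butyl of compound 3 goes with the stronger growth inhibition and the phenyl of compound 4 with the weaker. Nothing on hand gives a reason for this step.

With a single step, the compounds shown do not separate the entry of an aromatic ring from the rise in heavy-atom count, and cyclohexyl at this position on the shared core would bear directly on that question. Also open, as far as these compounds go, are how iodine, which compounds 1 and 2 carry on a much smaller structure, would read on the shared core, and whether an amine or a carboxylic acid at this position would move the number in either direction.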